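Aryl exchange on the saturated ring carbon: compound 3

The source may report more compounds than this note shows. Statements on the series, on what has been measured and on what is new or still open speak of the compounds shown alone.

Among the measured compounds shown here, compound 2 `COc1ccccc1C1CCCN1C(=O)C(Nc1ccccc1F)c1ccc(C(F)(F)F)cc1` stands at the low end of the two numbers so far: in an assay on HEK293 cells for antagonist activity at transient receptor potential M8 protein (Canis lupus familiaris), read by fluorescence and calcium flux, with a stated time of 5 min (on this read-out lower numbers stand for stronger inhibition and higher numbers for weaker inhibition), compound 2 gives 12 nM, while compound 1 `O=C(C(Nc1ccccc1F)c1ccc(C(F)(F)F)cc1)N1CCCC1c1ccc(F)cc1` gives 37 nM. For the measured compounds named here, the one measured step, a 3.1-fold lower number from compound 1 to compound 2 (0.49 log units; beyond the scatter), alters the same aryl group that the step to compound 3 `O=C(O)c1cccc(C2CCCN2C(=O)C(Nc2ccccc2F)c2ccc(C(F)(F)F)cc2)c1` alters: 3-carboxyphenyl in place of 2-methoxyphenyl on a saturated ring carbon. That step bears on the new one only loosely; it shows an aryl exchange at this position with a modest shift. Going by the values given here, a 3-carboxyphenyl has no precedent. Compound 3 is expected to come out weaker, a 13-fold higher number from compound 2 to compound 3 (1.10 log units; beyond the scatter), estimated at 150 nM with a range of 30 nM to 800 nM.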

Compound 3, half-maximal inhibitory concentration: 40 nM
Compound 3: the middle estimate sits 3.8-fold (0.57 log units) above what was measured, and the stated range covers the measured number.
By their numbers in this assay, from the lowest: compound 2; then compounds 1 and 3 (each within the scatter of the next).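

The 3-carboxyphenyl group is accepted on the saturated ring carbon in this assay: the exchange gives a 3.3-fold higher number from compound 2 to compound 3 (0.52 log units; beyond the scatter), and the comparison with the 4-fluorophenyl analogue gives a 1.1-fold higher number from compound 1 to compound 3 (0.03 log units; within the scatter). The aryl group at this position can therefore carry a carboxylic acid and still give a double-digit nanomolar-range number comparable to that of compound 1. Nothing at hand accounts for this result.

Open, going by these compounds, is whether the acid itself matters: a methyl ester, a primary amide or an amine on the same aryl ring would test that. Also open, on these data alone, is whether a methoxy group on this ring would combine with the acid.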